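From methoxy to cyano in a series at its limit

The source may report more compounds than this note shows. Statements on the series, on what has been measured and on what is new or still open speak of the compounds shown alone.

Compound 1 (`COc1ccc(-c2cnc(NC(=O)c3ncc[nH]3)n2C)cc1`) gives > 100000 nM in a toxicity assay on THP-1 cells (Homo sapiens) for inhibition (on this read-out higher numbers stand for lower toxicity in this test and lower numbers for higher toxicity in this test), as a limit and not a number. Compound 2 (`COc1ccc(-c2cnc(NC(=O)c3ccccc3O)n2C)cc1`) gives > 100000 nM in this assay as a limit too. Compound 3 (`COc1ccc(-c2cnc(NC(=O)c3cnco3)n2C)cc1`) gives > 100000 nM in this assay as a limit as well. What the three share is the limit of > 100000 nM in this assay, at which 3 of the 3 values shown sit, so far in this series.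

Compound 4 (`Cn1c(-c2ccc(C#N)cc2)cnc1NC(=O)c1ncc[nH]1`) carries cyano in place of methoxy on an aromatic carbon of a six-membered aromatic ring of carbon only, para to a large group (cyano in place of methoxy on an aromatic carbon).

The measured steps are a step that the two limits leave unreadable from compound 1 to compound 2 and a step that the two limits leave unreadable from compound 1 to compound 3 and a step that the two limits leave unreadable from compound 2 to compound 3 in the group on the carbonyl carbon. All three keep the methoxy, so none tests this change, and none has a readable size.

What is expected for compound 4 rests on compound 1 and its limit > 100000 nM in the absence of any contrary step. No step beyond the scatter is therefore expected in this assay in either direction. The expected move is a number no higher from compound 1 to compound 4 (the limit leaves the size open) as an estimate only. Compound 4 is estimated at 100000 nM with an expected range from 40000 nM to 200000 nM for a measured result.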

Compound 4, half-maximal cytotoxic concentration: > 100000 nM
Compound 4 was reported as a limit; the forecaster's own chance of this, stated with the estimate: 85%; the middle value lies on the limit itself.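

In this assay compound 4 gives > 100000 nM, a limit and not a number. Compound 1 also sits at a limit, so no new step can be read between compound 1 and compound 4: the limit of > 100000 nM in this assay, at which 4 of the 4 values shown sit.

Going by these compounds alone, with no compound here giving a number in this assay, the size and direction of any effect of cyano in place of methoxy stay open.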